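Cyclobutyl for cyclopropyl in a cell tolerance test

The source may hold more compounds than are shown below. What is called first, only, known or untested is meant among the compounds shown, and "the series" means these compounds.

In an ADME assay on MT4 cells (Homo sapiens) for cytotoxicity, read by MTT assay, with a stated time of 5 days (a higher number here means that more compound is tolerated, a lower number that less compound is tolerated), compound 1 `COc1cc2cc(C#N)ccc2c(OC)c1Oc1cc(NC(C)C)nc(Nc2ccc(C#N)cc2)n1` gives > 125000 nM and this is a limit, not a number. Compound 2 `COc1cc2cc(C#N)ccc2c(OC)c1Oc1cc(NC2CC2)nc(Nc2ccc(C#N)cc2)n1` gives > 125000 nM and this too is a limit, so compound 2 has no number of its own. The only other result is likewise a limit. Among the compounds with values here, the one measured step is a step that the two limits leave unreadable from compound 1 to compound 2 and it offers no size to carry forward. Compound 3 `COc1cc2cc(C#N)ccc2c(OC)c1Oc1cc(NC2CCC2)nc(Nc2ccc(C#N)cc2)n1` differs from compound 2 by cyclobutyl in place of cyclopropyl on a nitrogen on an aromatic ring. Within the data shown here, the only guide from compound 2 is the limit of > 125000 nM in this assay, at which 2 of the 2 values shown sit, and so no step beyond the scatter is expected in this assay for this change. The step expected is a number no higher from compound 2 to compound 3 (the limit leaves the size open) and no direction is favoured. For compound 3 the estimated value is 125000 nM with an expected range from 60000 nM to 250000 nM and another limit is the likeliest report.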

Compound 3, half-maximal cytotoxic concentration: > 125000 nM
Compound 3 gave a limit, no number (the forecaster's own chance of this, stated with the estimate: 80%); the middle value lies on the limit itself.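

In this assay, within the data shown here, compound 1, compound 2 and compound 3 all give a limit, not a number, so no step between them can be read. Left open is whether isopropyl, cyclopropyl and cyclobutyl differ at all in how much compound the cells tolerate, and at what concentration any of the three becomes harmful to them.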